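A few compounds are considered here, and "the series" means these few. Any claim that something is new, unique, unknown or untested is made for them only; others in the source may bear on it.

Of the compounds shown here, three have been measured in a functional assay, read by spectrophotometry, with a stated time of 2 h; a lower number here means a stronger inhibitor, a higher number a weaker inhibitor. Compound 1 `CCOC(=O)N1CCC(=NNC(=O)c2ccc(C)cc2)CC1` gives 75500 nM. Compound 2 `O=C(NN=C1CC(c2ccccc2)NC(c2ccccc2)C1)c1ccccc1` gives 42000 nM, and compound 3 `COc1ccc(C(=O)NN=C2CC(c3ccccc3)NC(c3ccccc3)C2)cc1` gives 75800 nM. Compound 3 has the highest of the three numbers, but compound 1 sits at practically the same number and compound 2 lies within the scatter of it, so none of the three can be called stronger or weaker than the others. Going by the values given here, the only step between two measured compounds that differ in a single place, a 1.8-fold higher number from compound 2 to compound 3 (0.26 log units; within the scatter), comes from a methoxy put in place of a hydrogen on an aromatic carbon, and it stays within the scatter.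

Compound 4 `O=C(NN=C1CC(c2ccccc2)NC(c2ccccc2)C1)c1ccc([N+](=O)[O-])cc1` differs from compound 3 by nitro in place of methoxy on an aromatic carbon. Among the compounds with values here, no measured pair shows a nitro entering or leaving, so the only guide is the methoxy step, which did nothing beyond the scatter. The expected step in this assay is therefore a 1.3-fold lower number from compound 3 to compound 4 (0.10 log units; within the scatter), nothing beyond the usual scatter. Compound 4 is estimated at 60000 nM, with a range from 20000 nM to 200000 nM.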

Compound 4, half-maximal inhibitory concentration: 88100 nM
Compound 4: the middle estimate sits 1.5-fold (0.17 log units) below what was measured, within the range that was stated.
By their numbers in this assay, from the lowest: compounds 2, 1, 3 and 4 (each within the scatter of the next, the first and the last beyond it).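

At this place on the aromatic ring, para to a large group, exchanging methoxy for nitro does not move the number in this assay beyond the scatter (a 1.2-fold higher number from compound 3 to compound 4 (0.07 log units; within the scatter)). Set against hydrogen, however, nitro gives the first step here to pass the scatter, a modest weakening (a 2.1-fold higher number from compound 2 to compound 4 (0.32 log units; beyond the scatter)), while methoxy at the same place stayed within it (a 1.8-fold higher number from compound 2 to compound 3 (0.26 log units; within the scatter)). Nothing available accounts for this small difference between the two groups.

An amine or a carboxylic acid on the same aromatic carbon would show whether any group can produce a much larger step at this place. Going by these compounds alone, the nitro change is also seen on only one core, so whether it would carry over to the core of compound 1 remains open.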